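Series notes: propyl for 2-fluorophenyl at the chain carbon

The source may report more compounds than this note shows. Statements on the series, on what has been measured and on what is new or still open speak of the compounds shown alone.

Measured compounds and their values:
- compound 1 `Cc1cccc(Cn2c(CN3CCN(C(=O)C4CCCCC4)CC3)nc3ccccc32)c1` gives 31.9%
- compound 2 `O=C(C1CC1)N1CCN(Cc2nc3ccccc3n2Cc2ccccc2F)CC1` gives 40.7%
- compound 3 `Cc1cccc(Cn2c(CN3CCN(C(=O)c4cccnc4)CC3)nc3ccccc32)c1` gives 24.5%

All three numbers come from an assay on isolated protein for inhibition of aldehyde dehydrogenase 1A1 (Homo sapiens), read by spectrophotometry, tested at 10 uM; on this read-out higher numbers stand for more inhibition at the one concentration tested (going by the name of the read-out) and lower numbers for less inhibition. Compound 2 holds the highest of the three numbers. Its nearest neighbour is compound 1, whose value sits within the scatter of compound 2, so no order between compound 2 and compound 1 is read from this. Compound 3 lies furthest, beyond the scatter below compound 2.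

Going by the values given here, the only step between measured compounds that differ in one place is a number 7.4 percentage points lower from compound 1 to compound 3 (within the scatter), a change on the carbonyl carbon that stays within the scatter.

Compound 4 `CCCCn1c(CN2CCN(C(=O)C3CC3)CC2)nc2ccccc21` is not yet measured. It differs from compound 2 in a different place: propyl in place of 2-fluorophenyl on a saturated chain carbon bound to an aromatic nitrogen. Among the compounds with values here, no measured step touches the group on the saturated chain carbon bound to the aromatic nitrogen, and no measured compound carries propyl there; compounds 1 and 3 differ from compound 2 in two places at once, so they give no single-place comparison. Within the data shown here, the one measured step, on the carbonyl side, was within the scatter and does not bear on this change.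

With nothing measured at this position, the expected change is a number 6.7 percentage points lower from compound 2 to compound 4 (within the scatter), not beyond the scatter in either direction. Compound 4 is estimated at 34%, with a range from 18% to 50%.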

Compound 4, a percentage reported as inhibition, at one concentration (the size of the read-out at that concentration, not a potency): 18.2%
Beside the measured number, compound 4's estimate is 15.8 percentage points above it, within the range that was stated.
By their numbers in this assay, from the lowest: compounds 4, 3, 1 and 2 (each within the scatter of the next, the first and the last beyond it).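

In this assay, going by these compounds alone, the first single-place reading at the saturated chain carbon bound to an aromatic nitrogen is a number 22.5 percentage points lower from compound 2 to compound 4 (beyond the scatter) on putting propyl in place of 2-fluorophenyl. This position therefore responds in a way the carbonyl side has not shown, since a number 7.4 percentage points lower from compound 1 to compound 3 (within the scatter) is the only step read there. The change removes the six-membered aromatic ring and the fluorine and brings in no ring, with no hydrogen-bond donor, acceptor or net charge on either side, but no measurement here accounts for the loss of inhibition.

From the compounds shown here alone, whether the step follows the loss of the ring, the loss of the fluorine or the shorter group stays open, and an unsubstituted phenyl, a cyclohexyl or a longer chain such as hexyl at this place would begin to separate these. Going by these compounds, the readings also give no potency, as each comes from one concentration, and it remains open whether the step holds with a group other than cyclopropyl on the carbonyl carbon.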